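Cyclopropyl for Cyclobutylmethyl on a Purine-like Core

The source may hold more compounds than are shown below. What is called first, only, known or untested is meant among the compounds shown, and "the series" means these compounds.

Measured compounds:
Compound 1 `c1nc(NC2CC2)c2ncn(CC3CCC3)c2n1` gives 10 mg/kg in a functional assay on the whole organism for antagonist activity, with Rattus norvegicus as the target; on this read-out lower numbers stand for an effect already at smaller amounts and higher numbers for an effect only at larger amounts of compound.
Compound 2 `c1nc(NC2CC2)c2ncn(C3CC3)c2n1` gives 4.5 mg/kg in this assay.
Compound 3 `O=CN(c1ncnc2c1ncn2CC1CCC1)C1CC1` gives 7 mg/kg in this assay.

Compound 1 and compound 2 share a core and differ only in one group: cyclopropyl in place of cyclobutylmethyl on an aromatic nitrogen. That change lowered the dose a 2.2-fold lower number from compound 1 to compound 2 (0.35 log units; beyond the scatter), a step that lies beyond the usual scatter of such measurements. Compound 3 carries the same cyclobutylmethyl group as compound 1 but differs from it at another place: formyl in place of hydrogen on a nitrogen on an aromatic ring. The values of compound 1 and compound 3 sit within the scatter of each other a 1.4-fold lower number from compound 1 to compound 3 (0.15 log units; within the scatter), so no order between them can be read off.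

Compound 4 `O=CN(c1ncnc2c1ncn2C1CC1)C1CC1` has not yet been measured. It stands to compound 3 exactly as compound 2 stands to compound 1: cyclopropyl in place of cyclobutylmethyl on an aromatic nitrogen. The place of the change is described in the same words for both pairs, so this is the same change on two cores that differ by the formyl group. Among the compounds with values here, with only one measured example of this change, the expectation rests on compound 1 and compound 2 alone: the dose for compound 4 is expected to fall from compound 3 by about the same step, a 2.2-fold lower number from compound 3 to compound 4 (0.34 log units; beyond the scatter), because the earlier change gave a 2.2-fold lower number from compound 1 to compound 2 (0.35 log units; beyond the scatter). Compound 4 is therefore estimated at 3.2 mg/kg, with a range from 1.5 mg/kg to 7 mg/kg.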

Compound 4, dose for half-maximal effect: 2.4 mg/kg
Estimate against measurement, compound 4: 1.3-fold (0.12 log units) above, within the range that was stated.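

In this assay, cyclopropyl in place of cyclobutylmethyl on an aromatic nitrogen, now on the core that carries the formyl group, gives a 2.9-fold lower number from compound 3 to compound 4 (0.46 log units; beyond the scatter), and this step cannot be told apart from the one seen on the core without formyl: the same change on two cores in this assay, a 2.2-fold lower number (0.35 log units; beyond the scatter) from compound 1 to compound 2 and a 2.9-fold lower number (0.46 log units; beyond the scatter) from compound 3 to compound 4, 1.3-fold (0.12 log units) apart, within the scatter of two such steps

Formyl in place of hydrogen, read on the two cyclopropyl compounds, gives a 1.9-fold lower number from compound 2 to compound 4 (0.27 log units; within the scatter), so this step stays too small to count as an effect of its own, and it also matches its counterpart on the cyclobutylmethyl core: the same change on two cores in this assay, a 1.4-fold lower number (0.15 log units; within the scatter) from compound 1 to compound 3 and a 1.9-fold lower number (0.27 log units; within the scatter) from compound 2 to compound 4, 1.3-fold (0.12 log units) apart, within the scatter of two such steps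

Together these pairs show that the cyclopropyl change carried over from one core to the other in this series, and that the two changes can be combined in one compound without the steps parting, but two cores are a small sample, so they do not show that the change would hold on a third core, and a dose in the whole animal does not say why the number falls.

Left open is how a methyl group or a longer chain on that aromatic nitrogen would compare with cyclopropyl. Also open, on these data alone, is whether an acetyl group in place of formyl would behave as formyl does here.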